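This account rests on a few compounds, and the source may have more. Where it says the series, first, only, none or still open, it means among the compounds named here.

The study concerns four related compounds built on two closely related cores. Compound 1 `O=C(CCCCC1CCSS1)NCc1cn(CCCOc2ccc3cc(-c4ccc(Br)cc4)c(=O)oc3c2)nn1` carries a 4-bromophenyl group on its core, and compound 2 `O=C(CCCCC1CCSS1)NCc1cn(CCCOc2ccc3cc(-c4ccc(Cl)c(Cl)c4)c(=O)oc3c2)nn1` differs from it in a single place: 3,4-dichlorophenyl in place of 4-bromophenyl on an aromatic carbon. Compound 3 `O=C(CCCCC1CCSS1)NCc1cn(CCCCCOc2ccc3cc(-c4ccc(Br)cc4)c(=O)oc3c2)nn1` carries the same 4-bromophenyl group on a second core; how the core of compound 3 differs from the core of compound 1 is not broken down here. Compound 4 `O=C(CCCCC1CCSS1)NCc1cn(CCCCCOc2ccc3cc(-c4ccc(Cl)c(Cl)c4)c(=O)oc3c2)nn1` is the partner of compound 3, differing from it by 3,4-dichlorophenyl in place of 4-bromophenyl on an aromatic carbon, the same change that separates compound 1 from compound 2, made at the same place.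

In a functional assay on PC-12 cells (Rattus norvegicus) for cytotoxicity, read by MTT assay, with stated times of 3 h and 2 h, tested at 50 uM (a higher number here means a stronger effect of the compound at the concentration tested, a lower number a weaker effect), compound 1 gives 74.7%. In the same setting compound 2 gives 54.8%, and the step of a number 19.9 percentage points lower from compound 1 to compound 2 (beyond the scatter) is recorded as beyond the usual scatter of the method. Compound 3 gives 53.6% in this assay; its value and that of compound 2 lie within the scatter of one another, while it stands well apart from compound 1.

Among the measured compounds shown here, only one earlier instance of the change is known, so the expectation for compound 4 rests on a single step. Because a number 19.9 percentage points lower from compound 1 to compound 2 (beyond the scatter) lowered the read-out, a drop of similar kind is expected when the same change is made to compound 3, though with caution since the core is not the same. The estimated step of a number 16.6 percentage points lower from compound 3 to compound 4 (beyond the scatter) is therefore expected to be downward. Compound 4 is expected to give about 37% in this assay, with a plausible range from 20% to 54%.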

Compound 4, a percentage reported as activity, at one concentration (the size of the read-out at that concentration, not a potency): 66.2%
The estimate for compound 4 lay 29.2 percentage points below the measured number, outside the stated range (above it).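

In this assay, the replacement of 4-bromophenyl by 3,4-dichlorophenyl did not carry over from one core to the other in the same direction: on the second core the read-out was a number 12.6 percentage points higher from compound 3 to compound 4 (beyond the scatter). The two steps disagree in direction and not merely in size, so within these two pairs the outcome of this change depends on the core that carries it: the same change on two cores in this assay, a number 19.9 percentage points lower (beyond the scatter) from compound 1 to compound 2 and a number 12.6 percentage points higher (beyond the scatter) from compound 3 to compound 4, 32.5 percentage points apart, beyond the scatter of two such steps What this does not show is why the direction reverses or whether any rule lies behind it, since two pairs are a very small basis, the difference between the two cores is not broken down here, and each read-out is the size of an effect at one concentration and not a potency.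

The compounds shown leave open whether the reversal is particular to this pair of aryl groups or would also appear with an unsubstituted phenyl or a 4-methoxyphenyl group at the same place. They also leave open how the same change would behave on a core carrying a longer chain, and so whether either of the two steps is the more typical one for the series.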